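Branching the linker: from methyl to propyl at the chain carbon

A few compounds are considered here, and "the series" means these few. Any claim that something is new, unique, unknown or untested is made for them only; others in the source may bear on it.

The series shares the core of compound 1 `O=C(O)c1ccccc1-c1ccc(CCc2ncc(CC3CCCCC3)[nH]2)cc1`, which in an in vitro functional assay on cells for agonist activity at Bombesin receptor subtype-3 (Mus musculus), read by luminescence and calcium flux (a higher number here means that more compound is needed for the effect, a lower number that less compound is needed), gives 7.3 nM. Compound 2 `CCCCc1cnc(Cc2ccc(-c3ccccc3C(=O)O)cc2)[nH]1` reaches only the limit of > 10000 nM in this assay, so its number is not known. Compound 3 `CCCCc1cnc(C(C)Cc2ccc(-c3ccccc3C(=O)O)cc2)[nH]1` gives 184 nM, the higher of the two numbers that this assay shows, since compound 1 sits at a lower value. The unmeasured compound 4 `CCCCc1cnc(C(CCC)Cc2ccc(-c3ccccc3C(=O)O)cc2)[nH]1` differs from compound 3 by ethyl in place of hydrogen on a saturated chain carbon, two bonds along the chain from an aromatic carbon. Going by the values given here, no measured pair in this set makes exactly this step, so the direction rests on compound 3 alone. A modest movement toward a lower value is expected, although a change within the scatter is equally plausible; the step from a 2.3-fold lower number from compound 3 to compound 4 (0.36 log units; beyond the scatter) is estimated. Compound 4 is therefore expected to give about 80 nM, within a range from 15 nM to 500 nM.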

Compound 4, half-maximal effective concentration: 165 nM
Beside the measured number, compound 4's estimate is 2.1-fold (0.31 log units) below it, within the range that was stated.
By their numbers in this assay, from the lowest: compound 1; then compounds 4 and 3 (each within the scatter of the next). At a limit, above all of these: compound 2.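

With a 1.1-fold lower number from compound 3 to compound 4 (0.05 log units; within the scatter) the change from methyl to propyl on this saturated chain carbon, two bonds along the chain from an aromatic carbon, gives no reading that can be told apart from the scatter in this assay. Going by these compounds alone, the earlier compounds showed only a single branched example, and compound 4 adds that this position accepts ethyl in place of hydrogen with the value held. Compound 2, which has no branch on this carbon, stands at a limit and not at a number: the limit of > 10000 nM in this assay, at which 1 of the 4 values shown sits.

On these data alone, it remains open whether a longer chain, a hydroxyl or an amine on this chain carbon would also hold the value. As far as these compounds go, it also remains open whether a propyl branch here would give a similar reading on the core of compound 1.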